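Removing an N-methyl group from a thienopyrimidine ether

This account rests on a few compounds, and the source may have more. Where it says the series, first, only, none or still open, it means among the compounds named here.

Measured compounds:
- compound 1, `c1cc(N2CCCCC2)nc(Nc2ccc(Oc3ncnc4sccc34)cc2)n1`, gives 4020 nM in a functional assay on A549 cells (Homo sapiens) for inhibition, read by MTT assay, with a stated time of 72 h; a higher number here means a weaker inhibitor, a lower number a stronger inhibitor
- compound 2, `CN(c1ccc(Oc2ncnc3ccsc23)cc1)c1nccc(N2CCCC2)n1`, gives 6510 nM in this assay
- compound 3, `CN(c1ccc(Oc2ncnc3sccc23)cc1)c1nccc(N2CCCC2)n1`, gives 15100 nM in this assay

Compound 3 stands highest of the three numbers, that is, it is the weakest inhibitor shown. Its nearest neighbour is compound 2, and the step of a 2.3-fold higher number from compound 2 to compound 3 (0.37 log units; beyond the scatter) came from swapping one bicyclic ether group for another. Compound 1 sits furthest away, with the lowest number of the three.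

Compound 4, `c1cc(N2CCCC2)nc(Nc2ccc(Oc3ncnc4sccc34)cc2)n1`, differs from compound 3 in one place: hydrogen in place of methyl on a nitrogen on an aromatic ring.

Within the data shown here, no measured step covers exactly this change. Among the measured compounds shown here, the only clue comes from compound 1, which carries the same hydrogen on that nitrogen and the same ether group as compound 4, yet differs from compound 4 in a second place as well, so its comparison with compound 3 is indirect. Because compound 1 gives 4020 nM while compound 3 gives 15100 nM, a lower number for compound 4 than for compound 3 seems the more likely outcome, but the size is uncertain. The expected step is a 2.7-fold lower number from compound 3 to compound 4 (0.44 log units; beyond the scatter). Compound 4 is therefore estimated at 5500 nM in this assay, with a range from 2000 nM to 15000 nM.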

Compound 4, half-maximal inhibitory concentration: 8100 nM
Compound 4: the middle estimate sits 1.5-fold (0.17 log units) below what was measured, and the stated range covers the measured number.
By their numbers in this assay, from the lowest: compounds 1, 2, 4 and 3 (each within the scatter of the next, the first and the last beyond it).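

In this assay, hydrogen in place of methyl on this nitrogen gives a 1.9-fold lower number from compound 3 to compound 4 (0.27 log units; within the scatter), so this pair offers no sign that the methyl group matters for the read-out, at least with this ether group and the pyrrolidin-1-yl ring in place. Among these compounds, compound 4 also gives the first direct look at the other ring on the shared core: pyrrolidin-1-yl in place of piperidin-1-yl gives a 2.0-fold higher number from compound 1 to compound 4 (0.30 log units; within the scatter), so that change, too, cannot be told apart from repeat-measurement noise here. No measurement among these data offers an explanation for either step.

Still open, going by these compounds, is how other groups on this nitrogen, such as ethyl or acetyl, or a morpholin-4-yl ring in place of pyrrolidin-1-yl on the aromatic carbon, would read in this assay. Among the compounds shown here, also open is whether hydrogen in place of methyl would give a similar step with the ether group of compound 2, since the only direct pair for this change carries the ether group of compound 3.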